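A few compounds are considered here, and "the series" means these few. Any claim that something is new, unique, unknown or untested is made for them only; others in the source may bear on it.

Measured so far in a functional assay on MCF7 cells (Homo sapiens) for antiproliferative activity, read by MTT assay, with a stated time of 48 h, tested at 12.5 uM; on this read-out lower numbers stand for a stronger effect and higher numbers for a weaker effect at the one concentration tested:
Compound 1, `OCC(O)Cn1nc2c(Br)c(Br)c(Br)c(Br)c2n1`, gives 116%.
Compound 2, `OC(CCn1nc2c(Br)c(Br)c(Br)c(Br)c2n1)c1ccccc1`, gives 113%.
Compound 3, `C[C@@H](O)CCn1nc2c(Br)c(Br)c(Br)c(Br)c2n1`, gives 86%.

Compound 2 stands second highest of these three numbers. Its nearest neighbour is compound 1, within the scatter, so no order between those two can be read. Among the compounds with values here, compound 3 lies furthest away, beyond the scatter; the one measured step, a number 30 percentage points lower from compound 1 to compound 3 (beyond the scatter), is of a modest size and concerns the chain on the ring nitrogen.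

Compound 4, `OC(CCn1nc2c(Br)c(Br)c(Br)c(Br)c2n1)c1ccc(F)cc1`, differs from compound 2 by fluoro in place of hydrogen on an aromatic carbon. Within the data shown here, no measured step touches a substituent on that six-membered ring, so nothing here speaks for a change in this assay beyond the scatter; the expected step is a number 1 percentage points lower from compound 2 to compound 4 (within the scatter). Compound 4 is thus estimated at 112%, between 95% and 128%.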

Compound 4, a percentage reported as activity, at one concentration (the size of the read-out at that concentration, not a potency): 109%
Beside the measured number, compound 4's estimate is 3 percentage points above it, within the range that was stated.
By their numbers in this assay, from the lowest: compound 3; then compounds 4, 2 and 1 (each within the scatter of the next).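

Going from phenyl to 4-fluorophenyl gives a number 4 percentage points lower from compound 2 to compound 4 (within the scatter) in this assay and is the first view of a substituent on this ring, which the earlier compounds did not offer. At this place, para to a large group, a single fluoro atom therefore produces no change that can be told from the scatter. Nothing measured here offers an explanation for this result. Going by these compounds, whether a larger group at this place, such as methoxy or an amine, would behave the same stays open. So does whether fluoro elsewhere on the ring would.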